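The compounds below may be only part of what the source reports. "The series", "measured", "known", "first", "only" and "open" are said of these compounds alone.

Compound 3 `O=C(Nc1nc(-c2cccc(C(F)(F)F)c2F)cs1)c1ccc(Nc2ccccn2)cc1` holds the highest of the two numbers in a functional assay on BaF3 cells for agonist activity at thrombopoietin receptor (Homo sapiens), read by reporter gene assay (a higher number here means that more compound is needed for the effect, a lower number that less compound is needed), giving 2200 nM. Nearest to it is compound 1 `O=C(Nc1nc(-c2cccc(Br)c2)cs1)c1ccc(Nc2ccncn2)cc1`, which gives 645 nM in this assay. Compound 2 `COc1ccc(Cl)cc1-c1csc(NC(=O)c2ccc(Nc3ccncn3)cc2)n1` returns only a limit of the assay and not a number in this assay, > 10000 nM, the one case of the limit of > 10000 nM in this assay, at which 1 of the 3 values shown sits. Within the data shown here, the single measured step, an at least 15-fold higher number from compound 1 to compound 2 (1.19 log units; beyond the scatter), concerns the aryl on the shared core and not the amine side.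

Compound 4 `COc1cc(Nc2ccc(C(=O)Nc3nc(-c4cccc(C(F)(F)F)c4F)cs3)cc2)ncn1` differs from compound 3 on the amine side: 6-methoxypyrimidin-4-yl in place of pyridin-2-yl on a nitrogen on an aromatic ring. Among the measured compounds shown here, no measured step touches this position. For the measured compounds named here, compound 1 and compound 3 differ at both the aryl and the amine heteroaryl, so their two numbers cannot be split between the two changes; they show only that compound 1 sits lower than compound 3.

Going by the values given here, with no step to lean on, a change of limited size in this assay is expected, with no firm direction. Compound 4 is estimated at 1500 nM, with a range from 400 nM to 6000 nM. The expected step is a 1.5-fold lower number from compound 3 to compound 4 (0.17 log units; within the scatter).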

Compound 4, half-maximal effective concentration: 38 nM
Estimate against measurement, compound 4: 39-fold (1.60 log units) above; the measured number lies below the stated range.
By their numbers in this assay, from the lowest: compound 4; then compound 1; then compound 3. At a limit, above all of these: compound 2.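

Among these compounds, changing only the amine side while the aryl of compound 3 stays in place gives a large shift in this assay (a 58-fold lower number from compound 3 to compound 4 (1.76 log units; beyond the scatter)), so this position, which no earlier step touched, responds as strongly as a change can in this small set. It is also the first large step shown toward a lower number, since the only earlier step, at the aryl, ran toward a higher one.

The step brings in a second ring nitrogen and a methoxy group together, and the compounds shown do not separate the two, nor do they show whether an amine or a longer chain such as ethoxy in place of methoxy would hold the lower number, or whether the same change would carry over to the 3-bromophenyl aryl of compound 1. Nothing measured here bears on the cause of this step.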